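The compounds below may be only part of what the source reports. "The series", "measured", "known", "first", "only" and "open" are said of these compounds alone.

Working notes on a small set of analogues sharing one core, tested in a functional assay on MDA-MB-435S cells (Homo sapiens) for cytotoxicity, read by MTT assay, with a stated time of 72 h; a higher number here means a weaker inhibitor, a lower number a stronger inhibitor. Compound 1 `O=c1cc(CSc2nc3ccccc3s2)oc2ccccc12` reaches only the limit of the assay, giving > 25000 nM. Compound 2 `Cc1nnc(SCc2cc(=O)c3ccccc3o2)s1` likewise returns a limit rather than a number, with > 25000 nM. Compound 3 `Cc1nnc(SCc2cc(=O)c3cc(Cl)ccc3o2)o1` also stops at the limit, > 25000 nM. On the numbers shown, compound 3 therefore stands nowhere distinct: every value is the same limit, as summed up in the limit of > 25000 nM in this assay, at which 3 of the 3 values shown sit, so no measured step can be read and no compound can be ranked against another.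

The next compound, compound 4 `Cc1nnc(SCc2cc(=O)c3ccccc3o2)o1`, differs from compound 3 by hydrogen in place of chloro on an aromatic carbon. For the measured compounds named here, no step between measured compounds is available to calibrate this change. With all three neighbours at the limit, the expectation for this assay is no shift beyond the scatter, and most likely another limit rather than a number. Compound 4 is accordingly expected to give about 40000 nM, within 15000 nM to 150000 nM. The implied step is estimated as a step that the limit leaves unreadable from compound 3 to compound 4, essentially flat.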

Compound 4, half-maximal inhibitory concentration: > 25000 nM
Compound 4 ended at the assay's limit; the forecaster's own chance of this, stated with the estimate: 85%; the middle value does not contradict the limit.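

Compound 4 returns a limit rather than a number in this assay, so the steps to it from compound 3 and from compound 2 cannot be read: the limit of > 25000 nM in this assay, at which 4 of the 4 values shown sit. The compounds shown leave open which change to the shared core, if any, would give a measurable value.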